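The compounds below may be only part of what the source reports. "The series", "measured", "known", "first", "only" and "open" are said of these compounds alone.

Working notes on the series. Among the measured compounds shown here, compound 3 `O=C(COc1ccc2c(=O)ccoc2c1)Nc1cccc(NC(=O)c2ccc(F)cc2)c1` gives 54 nM in an assay on isolated protein for inhibition of Rho-associated protein kinase 2 (Homo sapiens), read by scintillation counting, radiometric assay and 33P incorporation, with a stated time of 40 min, in the presence of a further agent that is not named here (a lower number here means a stronger inhibitor, a higher number a weaker inhibitor), and is the only compound with a number rather than a limit. Compound 1 `CN(C)c1ccc(C(=O)Nc2cccc(NC(=O)COc3ccc4c(c3)OCCO4)c2)cc1` sits at a limit, > 10000 nM in this assay. Compound 2 `CN(C)c1ccc(C(=O)Nc2cccc(NC(=O)COc3ccc4occc(=O)c4c3)c2)cc1` also sits at a limit, > 10000 nM in this assay. The change a step that the two limits leave unreadable from compound 1 to compound 2 is thus unreadable, as the limit of > 10000 nM in this assay, at which 2 of the 3 values shown sit, shows. Compound 4 `Cn1ccc(S(=O)(=O)Nc2cccc(NC(=O)COc3ccc4c(=O)ccoc4c3)c2)n1` is not yet measured. Compound 4 differs from compound 3 by a group of 9 heavy atoms (4 carbon, 2 nitrogen, 2 oxygen, 1 sulfur; one five-membered aromatic ring with 2 hetero atoms) in place of a group of 9 heavy atoms (7 carbon, 1 oxygen, 1 fluorine; one six-membered aromatic ring of carbon only), on a nitrogen on an aromatic ring. For the measured compounds named here, no measured step touches this position; the only measured step concerns the group on the oxygen on the saturated carbon, and it gives no size. Going by the values given here, with no precedent, the step from compound 3 to compound 4 is expected to be a 9.3-fold higher number from compound 3 to compound 4 (0.97 log units; beyond the scatter), with wide uncertainty in either direction. Compound 4 is estimated at 500 nM, between 60 nM and 8000 nM.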

Compound 4, half-maximal inhibitory concentration: 1350 nM
Estimate against measurement, compound 4: 2.7-fold (0.43 log units) below, and the stated range covers the measured number.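

On the nitrogen on an aromatic ring, replacing (4-fluorophenyl)carbonyl with a group carrying a five-membered aromatic ring with 2 hetero atoms gives a 25-fold higher number from compound 3 to compound 4 (1.40 log units; beyond the scatter). Among the compounds shown here, this is the first readable size of a change, and it shows that activity depends on the group at this position. Nothing measured here gives a cause for this step.

The compounds shown leave open whether the change from carbonyl to sulfonyl or the change of ring carries this step, as the two come together in compound 4. A 4-fluorobenzenesulfonyl group at this position would separate them.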